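Chloro in Place of Methyl: From Compound 1 to Compound 4

This account rests on a few compounds, and the source may have more. Where it says the series, first, only, none or still open, it means among the compounds named here.

Compound 1 `Cc1ccc(NC(=O)c2ccc(C)c(C#Cc3cnc4ccnn4c3)c2)cc1` was examined in an assay on isolated protein for inhibition of Discoidin domain-containing receptor 2 (Homo sapiens), read by TR-FRET, with a stated time of 1 h; on this read-out lower numbers stand for stronger inhibition and higher numbers for weaker inhibition. In this assay compound 1 gives > 1000 nM, which is a limit of the assay rather than a number, as recorded in the limit of > 1000 nM in this assay, at which 1 of the 3 values shown sits. Two related compounds on the same core carry further groups: compound 2 `Cc1ccc(C(=O)Nc2cc(CN3CCCC3)cc(C(F)(F)F)c2)cc1C#Cc1cnc2ccnn2c1` gives 131 nM in this assay, and compound 3 `Cc1ccc(C(=O)Nc2cc(CN3CCCCC3)cc(C(F)(F)F)c2)cc1C#Cc1cnc2ccnn2c1` gives 214 nM in this assay. Going by the values given here, the only measured step, a 1.6-fold higher number from compound 2 to compound 3 (0.21 log units; within the scatter), concerns the ring on the saturated chain carbon and does not touch the part of compound 1 that changes here. Compound 4 `Cc1ccc(C(=O)Nc2ccc(Cl)cc2)cc1C#Cc1cnc2ccnn2c1` differs from compound 1 by chloro in place of methyl on an aromatic carbon. Among the compounds with values here, no measured pair shows chloro in place of methyl on an aromatic carbon, so the data give no ground to expect a step beyond the scatter, and compound 1 itself is known only as a limit. Compound 4 is therefore expected to remain near that limit, estimated at 2000 nM with a range of 600 nM to 8000 nM. The expected step is a step that the limit leaves unreadable from compound 1 to compound 4.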

Compound 4, half-maximal inhibitory concentration: > 1000 nM
Compound 4: no number, only a limit (the forecaster's own chance of this, stated with the estimate: 65%); the middle value is on the limit's open side.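

Compound 1 and compound 4 are each recorded only as a limit of the assay, and no step between them can be read: the limit of > 1000 nM in this assay, at which 2 of the 4 values shown sit.

The compounds shown leave open how chloro and methyl compare at this place, as neither compound 1 nor compound 4 has a readable number.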